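A few compounds are considered here, and "the series" means these few. Any claim that something is new, unique, unknown or untested is made for them only; others in the source may bear on it.

Compound 1 `Cc1nn(-c2cccc(CN)c2)c2c(F)c(-c3ccc(N4CCCC4=O)cc3)ccc12` and compound 2 `CN(C)Cc1nccn1-c1ccc(-c2ccc3c(C(N)=O)nn(-c4ccc5onc(N)c5c4)c3c2F)c(F)c1` share a core and were both tested in an assay on isolated protein for inhibition of Trypsin (Homo sapiens); a lower number here means a stronger inhibitor, a higher number a weaker inhibitor. In this assay compound 1 gives 702 nM. In this assay compound 2 reaches only > 10000 nM, which is a limit of the assay rather than a measured number. Of the two values shown, this is the limit of > 10000 nM in this assay, at which 1 of the 2 values shown sits. Compound 3 `CN(C)CCN(c1ccccc1)c1ccc(-c2ccc3c(C(N)=O)nn(-c4ccc5onc(N)c5c4)c3c2F)c(F)c1` has not yet been measured. It differs from compound 2 by (2-(dimethylamino)ethyl)(phenyl)amino in place of 2-((dimethylamino)methyl)-1H-imidazol-1-yl on an aromatic carbon. Going by the values given here, no pair of measured compounds shows a change of this kind, and since compound 2 stands at a limit, the size of the step in this assay cannot be read from numbers. The expectation is that the step of an at least 1.2-fold lower number from compound 2 to compound 3 (0.09 log units; that floor lies within the scatter) is none beyond the scatter, with weak inhibition remaining. Compound 3 is therefore estimated at 8000 nM, with a likely range from 2500 nM to 30000 nM.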

Compound 3, inhibition constant: > 10000 nM
Compound 3 gave a limit, no number; the forecaster's own chance of this, stated with the estimate: 50%; middle value at least 1.2-fold (0.09 log units) away from the limit.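

In this assay compound 3 gives > 10000 nM, a limit of the assay and not a number. Compound 2 also stands at a limit, and the step between compound 2 and compound 3 cannot be read. Left open is how weak both compounds really are in this assay, and whether exchanging the two groups changes the value at all.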